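The compounds below may be only part of what the source reports. "The series", "measured", "known", "first", "only" and "open" are said of these compounds alone.

Measured in a functional assay on A549 cells (Homo sapiens) for antiproliferative activity, read by CCK-8 assay, with a stated time of 72 h; on this read-out lower numbers stand for stronger inhibition and higher numbers for weaker inhibition:
- compound 1 `C/C(=N\O)c1ccc(OCc2ccc(C(=O)NO)cc2)cc1`: 8930 nM
- compound 2 `Nc1ccccc1NC(=O)/C=C/c1ccc(COc2ccccc2)cc1`: > 32000 nM (a limit of the assay, not a number)
- compound 3 `CC(C)c1ccc(OCc2ccc(C(=O)Nc3ccccc3N)cc2)cc1`: 7460 nM

Two of these compounds gave real numbers: compound 1 reads 8930 nM and compound 3 reads 7460 nM, values that lie within the usual scatter of each other. Compound 2 is different, since it stands at the limit of > 32000 nM in this assay, at which 1 of the 3 values shown sits. Its reading shows only where the measurement ran out, so it cannot be placed exactly on the scale.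

Compound 4 `Nc1cnccc1NC(=O)/C=C/c1ccc(COc2ccccc2)cc1` keeps the rest of compound 2 and changes one group, with 3-aminopyridin-4-yl in place of 2-aminophenyl on an amide-type nitrogen. For the measured compounds named here, no measured pair of compounds shows what this swap does in this assay, so there is no direct precedent to scale it against. The starting point is all there is to go on, and compound 2 offers only the limit > 32000 nM. The working expectation is therefore no change beyond the scatter, in neither direction, and the assay may well report a limit again. The expected step of a number no higher from compound 2 to compound 4 (the limit leaves the size open) is accordingly small. For compound 4 the estimated value is 32000 nM, with an expected range of 13000 nM to 70000 nM.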

Compound 4, half-maximal inhibitory concentration: > 32000 nM
Compound 4 ended at the assay's limit; the forecaster's own chance of this, stated with the estimate: 65%; the middle value lies on the limit itself.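

Putting 3-aminopyridin-4-yl in place of 2-aminophenyl gives no readable step, because compound 2 and compound 4 both stand at a limit of this assay and not at a number: the limit of > 32000 nM in this assay, at which 2 of the 4 values shown sit. The compounds shown leave open how far each lies beyond that limit, and so whether this swap changes activity at all.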